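The source may report more compounds than this note shows. Statements on the series, on what has been measured and on what is new or still open speak of the compounds shown alone.

Measured in an assay on membranes from brain for displacement of a labelled ligand from Sigma non-opioid intracellular receptor 1 (Cavia porcellus), read by scintillation counting, with a stated time of 120 min; on this read-out lower numbers stand for stronger inhibition and higher numbers for weaker inhibition:
compound 1 `c1ccc(CN2CCC3(CC2)OCCc2cc(-c4ccccc4)sc23)cc1`: 2.4 nM
compound 2 `COC1Cc2cc(-c3ccc(C#N)cc3)sc2C2(CCN(Cc3ccccc3)CC2)O1`: 20 nM
compound 3 `COC1Cc2cc(-c3ccc(-c4ccccc4)cc3)sc2C2(CCN(Cc3ccccc3)CC2)O1`: 211 nM

Compound 2 stands second highest of the three numbers: compound 1 gives a lower number, and compound 3 a higher one, both gaps beyond the scatter. Among the measured compounds shown here, the only single-place step among the measured compounds is an 11-fold higher number from compound 2 to compound 3 (1.02 log units; beyond the scatter), which shows that what sits on the aryl group attached to the thiophene moves this assay strongly.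

Compound 4 `COC1Cc2ccsc2C2(CCN(Cc3ccccc3)CC2)O1` differs from compound 2 by hydrogen in place of 4-cyanophenyl on an aromatic carbon. For the measured compounds named here, no measured step removes that aryl group altogether, so the bearing of the measured data is indirect. Going by the values given here, all three measured compounds carry an aryl group at that position, and the one measured step there, from cyano to phenyl, changed the number far beyond the scatter. The removal of the whole group is therefore expected to shift this assay as well; a higher number is taken as more likely than a lower one, with a wide margin. Compound 4 is estimated at 80 nM, between 15 nM and 500 nM, an expected step of a 4.0-fold higher number from compound 2 to compound 4 (0.60 log units; beyond the scatter).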

Compound 4, inhibition constant: 1.9 nM
Beside the measured number, compound 4's estimate is 42-fold (1.62 log units) above it; measured number below the stated range.
By their numbers in this assay, from the lowest: compounds 4 and 1 (each within the scatter of the next); then compound 2; then compound 3.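

In this assay, an 11-fold lower number from compound 2 to compound 4 (1.02 log units; beyond the scatter), so an aryl group on the aromatic carbon next to the ring sulfur is not needed for a low number, and here the 4-cyanophenyl group costs affinity rather than adding it. Together with an 11-fold higher number from compound 2 to compound 3 (1.02 log units; beyond the scatter), this gives a rising order among the methoxy-bearing compounds: hydrogen, then 4-cyanophenyl, then the biphenyl group of compound 3; compound 1 carries a phenyl group with 2.4 nM, but it also lacks the methoxy group, so it cannot be placed in this order. No measurement shown accounts for this order.

Still open, as far as these compounds go, is whether a small group on this carbon, such as methyl, chlorine or an aminomethyl chain, keeps the number of compound 4. An unsubstituted phenyl group on the methoxy-bearing core would also show how much of the step belongs to the nitrile.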